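The source may report more compounds than this note shows. Statements on the series, on what has been measured and on what is new or still open speak of the compounds shown alone.

Compound 1 `Cc1cc2c(C(N)=O)cccc2n1-c1nc2c(c(NCc3ccccc3)n1)COCC2`: 146 nM
Compound 2 `CC#CCNC(=O)c1cccc2c1cc(C)n2-c1nc2c(c(NCc3ccccc3)n1)CCCC2`: 723 nM

In a functional assay on MIA PaCa-2 cells (Homo sapiens) for antiproliferative activity (on this read-out higher numbers stand for an effect only at larger amounts of compound and lower numbers for an effect already at smaller amounts), compound 1 gives 146 nM, the lowest of the two numbers. Compound 2 gives 723 nM. The gap between these two compounds lies beyond the scatter. Compound 3 `C#CC(=O)Nc1cccc2c1cc(C)n2-c1nc2c(c(NCc3ccccc3)n1)COCC2` keeps the rest of compound 1 and carries (ethynylcarbonyl)amino in place of carbamoyl on an aromatic carbon. For the measured compounds named here, no measured pair shows this change alone, so the expectation in this assay is only a moderate move toward higher numbers, with compound 2 at 723 nM as the sole other reference. The estimated step is a 2.1-fold higher number from compound 1 to compound 3 (0.31 log units; beyond the scatter). For compound 3 the expected value is 300 nM, with an estimated range of 70 nM to 1300 nM.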

Compound 3, half-maximal effective concentration: 78.7 nM
Compound 3: the middle estimate sits 3.8-fold (0.58 log units) above what was measured; the range from low to high includes it.
By their numbers in this assay, from the lowest: compounds 3 and 1 (each within the scatter of the next); then compound 2.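

In this assay the swap of carbamoyl for (ethynylcarbonyl)amino on this aromatic carbon gives a 1.9-fold lower number from compound 1 to compound 3 (0.27 log units; within the scatter) and so leaves the read-out within the scatter. This position of the core of compound 1 therefore accepts the group of 5 heavy atoms, with its triple bond, in place of the group of 3 without a shift that can be told from repeat scatter. No measurement shown bears on why the two groups read alike. Open, as far as these compounds go, is whether an amine, a carboxylic acid or a saturated propanoylamino group on this carbon would read the same, and so whether the triple bond matters at all.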